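The source may hold more compounds than are shown below. What is called first, only, known or untested is meant among the compounds shown, and "the series" means these compounds.

Of the compounds shown here, two have been tested so far in a functional assay on liver (Rattus norvegicus, strain Sprague-Dawley) for inhibition, with a stated time of 1 h; a higher number here means a weaker inhibitor, a lower number a stronger inhibitor. Compound 1 `COc1cc(C2Oc3cc([C@H]4Oc5cc(O)cc(O)c5C(=O)[C@@H]4O)ccc3OC2COC(=O)c2cc(OC)c(OC)c(OC)c2)ccc1O` gives 25700 nM, and compound 2 `COc1cc(C2Oc3cc([C@H]4Oc5cc(O)cc(O)c5C(=O)[C@@H]4O)ccc3OC2COC(=O)c2cccc(Cl)c2)ccc1O` gives 14200 nM. The two differ by 3-chlorophenyl in place of 3,4,5-trimethoxyphenyl on a carbonyl carbon, and the step is a 1.8-fold lower number from compound 1 to compound 2 (0.26 log units; within the scatter). Compound 2 therefore stands level with compound 1 and cannot be ranked against it.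

Compound 3 `COc1cc(C2Oc3cc([C@H]4Oc5cc(O)cc(O)c5C(=O)[C@@H]4O)ccc3OC2COC(=O)c2cc(N)cc([N+](=O)[O-])c2)ccc1O` keeps the shared core and alters the same spot, with 3-amino-5-nitrophenyl in place of 3-chlorophenyl on a carbonyl carbon. Among the compounds with values here, only one measured step bears on this change, the one at that same carbonyl carbon, and it is a 1.8-fold lower number from compound 1 to compound 2 (0.26 log units; within the scatter). Within the data shown here, that is thin evidence, and no tested compound carries 3-amino-5-nitrophenyl, so a surprise remains possible in either direction. Among the measured compounds shown here, still, the one swap seen here stayed small, so no shift beyond the scatter is expected in this assay. The estimated change is a 1.3-fold higher number from compound 2 to compound 3 (0.10 log units; within the scatter), with no firm direction. For compound 3 the expected value is 18000 nM, with an estimated range of 7000 nM to 45000 nM.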

Compound 3, half-maximal inhibitory concentration: 200 nM
For compound 3 the middle estimate is 90-fold (1.95 log units) above the measured one; the whole stated range lies above it.
By their numbers in this assay, from the lowest: compound 3; then compounds 2 and 1 (each within the scatter of the next).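

At this carbonyl carbon, the choice of aromatic group can matter far more than the first two compounds suggested: in this assay, 3-amino-5-nitrophenyl in place of 3-chlorophenyl gives a 71-fold lower number from compound 2 to compound 3 (1.85 log units; beyond the scatter), and the same group in place of 3,4,5-trimethoxyphenyl gives a 130-fold lower number from compound 1 to compound 3 (2.11 log units; beyond the scatter). Both steps lie beyond the scatter, so compound 3 is the strongest inhibitor of the three, and the position is clearly sensitive to what it carries, even though the first swap produced no readable change. The entering group keeps a six-membered aromatic ring of carbon but counts hydrogen-bond donors and acceptors where 3-chlorophenyl has none; no measurement here explains why the number falls so sharply.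

Compound 3 brings in the amino and nitro groups together, so the compounds shown cannot say whether one of them alone accounts for the step, a question that 3-aminophenyl and 3-nitrophenyl would separate. Going by these compounds, it also remains open whether a different group in place of the nitro, such as a carboxylic acid or a nitrile, would keep the number this low.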